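A few compounds are considered here, and "the series" means these few. Any claim that something is new, unique, unknown or untested is made for them only; others in the source may bear on it.

Compound 1, `CNC(=O)c1cncc(NS(=O)(=O)c2cc(Cl)ccc2OC)c1`, gives 109 nM.
Compound 2, `COc1ccc(C#N)cc1S(=O)(=O)Nc1cnc2ccccc2c1`, gives 38 nM.

In an assay on isolated protein for inhibition of alkaline phosphatase, tissue-nonspecific isozyme (Homo sapiens) (a higher number here means a weaker inhibitor, a lower number a stronger inhibitor), compound 1 stands with the higher of the two numbers; compound 2 gives the lower one, and the gap between the two lies beyond the scatter. Compound 3, `COc1ccc(Cl)cc1S(=O)(=O)Nc1cncc(C(=O)N2CCN(C)CC2)c1`, differs from compound 1 in one place: 4-methylpiperazin-1-yl in place of methylamino on a carbonyl carbon. Within the data shown here, no measured pair shows this change, so nothing measured tells its size. On what is shown, the step of a 1.1-fold higher number from compound 1 to compound 3 (0.04 log units; within the scatter) is expected to be of no size beyond the scatter. Compound 3 is estimated at 120 nM, within a range from 40 nM to 360 nM.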

Compound 3, half-maximal inhibitory concentration: 671 nM
The estimate for compound 3 lay 5.6-fold (0.75 log units) below the measured number; measured number outside the range, above it.
By their numbers in this assay, from the lowest: compound 2; then compound 1; then compound 3.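

In this assay the group on the carbonyl carbon is not indifferent: 4-methylpiperazin-1-yl in place of methylamino gives a 6.2-fold higher number from compound 1 to compound 3 (0.79 log units; beyond the scatter) and takes compound 3 well away from compound 1. Among these compounds, the single change removes a hydrogen-bond donor and brings in a six-membered non-aromatic ring, and this one pair cannot separate those two differences. Nothing measured here accounts for the step. As far as these compounds go, whether dimethylamino, morpholin-4-yl or a longer chain on the same carbonyl carbon would track with methylamino or with 4-methylpiperazin-1-yl remains open.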